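The source may hold more compounds than are shown below. What is called first, only, known or untested is meant among the compounds shown, and "the series" means these compounds.

Three amino-acid-bearing quinones from the series have numbers in a functional assay on Fem-X cells (Homo sapiens) for cytotoxicity, read by MTT assay, with a stated time of 72 h; a lower number here means a stronger inhibitor, a higher number a weaker inhibitor. Compound 1 `CC1=CCC[C@H]2[C@](C)(CC3=CC(=O)C=C(NCCC(=O)O)C3=O)[C@@H](C)CC[C@]12C` gives 20200 nM in this assay. Compound 2 `CC(C)(C)C1=CC(=O)C=C(NCC(=O)O)C1=O` gives 34300 nM in this assay. Compound 3 `CC(C)[C@@H](NC1=CC(=O)C=C(C(C)(C)C)C1=O)C(=O)O` gives 24600 nM in this assay. On these three numbers compound 2 stands highest, but compound 3 and compound 1 both lie within the scatter of it.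

Compound 4 `CSCC[C@H](NC1=CC(=O)C=C(C(C)(C)C)C1=O)C(=O)O` differs from compound 2 by 2-(methylsulfanyl)ethyl in place of hydrogen on a saturated chain carbon bound to an amine nitrogen and a carbonyl carbon. Going by the values given here, the only measured step that bears on this is a 1.4-fold lower number from compound 2 to compound 3 (0.14 log units; within the scatter), a chain entering at the same place, and it stayed within the scatter. No step beyond the scatter is therefore expected here, and the expected step is a 1.3-fold lower number from compound 2 to compound 4 (0.12 log units; within the scatter). Compound 4 is estimated at 26000 nM in this assay, with a range of 11000 nM to 60000 nM.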

Compound 4, half-maximal inhibitory concentration: 34800 nM
Beside the measured number, compound 4's estimate is 1.3-fold (0.13 log units) below it; measured number inside the range.
By their numbers in this assay, from the lowest: compounds 1, 3, 2 and 4 (each within the scatter of the next).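

On the saturated chain carbon bound to an amine nitrogen and a carbonyl carbon, 2-(methylsulfanyl)ethyl in place of hydrogen gives a 1.0-fold higher number from compound 2 to compound 4 (0.01 log units; within the scatter) in this assay. Isopropyl at the same place gives a 1.4-fold lower number from compound 2 to compound 3 (0.14 log units; within the scatter), so two different chains now enter there and neither step leaves the scatter. The sulfur-bearing chain thus adds no measurable shift at this place. From the compounds shown here alone, whether a chain ending in an amine, or a benzyl group, would move the number at this carbon remains open. Nothing in hand explains why the number holds across these changes.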